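Aryl sulfonate series: methyl to methoxy on the phenoxy ring

The source may report more compounds than this note shows. Statements on the series, on what has been measured and on what is new or still open speak of the compounds shown alone.

All values below come from a functional assay on MCF7 cells (Homo sapiens) for antiproliferative activity, read by sulforhodamine B assay, with a stated time of 48 h; a higher number here means a weaker inhibitor, a lower number a stronger inhibitor.
Compound 1 `Cc1cccc(OS(=O)(=O)c2ccc(N3CCN(C)C3=O)cc2)c1` gives 5100 nM.
Compound 2 `COc1cccc(OS(=O)(=O)c2ccc(N3CCN(C)C3=O)cc2)c1` gives 3000 nM.
Compound 3 `Cc1ccc(OS(=O)(=O)c2ccc(N3CCN(C)C3=O)cc2)cc1` gives only a limit of this assay, > 100000 nM.

Between compound 1 and compound 2 the change is methoxy in place of methyl on an aromatic carbon, and the step is a 1.7-fold lower number from compound 1 to compound 2 (0.23 log units; within the scatter). Between compound 1 and compound 3 the cores differ by 4-methylphenyl in place of 3-methylphenyl on an oxygen; the step is an at least 19-fold higher number from compound 1 to compound 3 (1.29 log units; beyond the scatter), and from compound 2 the step is an at least 33-fold higher number from compound 2 to compound 3 (1.52 log units; beyond the scatter). Both rest on (the limit of > 100000 nM in this assay, at which 1 of the 3 values shown sits).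

Compound 4 `COc1ccc(OS(=O)(=O)c2ccc(N3CCN(C)C3=O)cc2)cc1` has not been measured. It differs from compound 3 by methoxy in place of methyl on an aromatic carbon. The place is not the same as in the first pair: there the group sits meta to a large group, here para to a large group, so this is the same kind of change, not the same one. For compound 4 a step that the limit leaves unreadable from compound 3 to compound 4 is expected because a 1.7-fold lower number from compound 1 to compound 2 (0.23 log units; within the scatter) stayed within the scatter. Compound 4 is therefore estimated at 150000 nM, between 40000 nM and 600000 nM.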

Compound 4, half-maximal inhibitory concentration: 95000 nM
Beside the measured number, compound 4's estimate is 1.6-fold (0.20 log units) above it, and the stated range covers the measured number.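

In this assay, methoxy in place of methyl on an aromatic carbon now stands on two cores, and no difference between the two outcomes can be read: the same change on two cores in this assay, a 1.7-fold lower number (0.23 log units; within the scatter) from compound 1 to compound 2 and an at least 1.0-fold lower number (0.02 log units; that floor lies within the scatter) from compound 3 to compound 4; the limit leaves it open whether they differ
On the second core the step is only a floor (an at least 1.0-fold lower number from compound 3 to compound 4 (0.02 log units; that floor lies within the scatter)). Compound 3 sits at a limit of the assay (> 100000 nM), so the size of the change on its core stays unread, and the result neither confirms nor rules out that the change carries over unchanged. The large steps that can be read do not come from this change, since compound 4 remains far weaker than the two compounds carrying the other aryl group (a 32-fold higher number from compound 2 to compound 4 (1.50 log units; beyond the scatter); a 19-fold higher number from compound 1 to compound 4 (1.27 log units; beyond the scatter)), the second of these steps also including the methyl to methoxy exchange.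

The compounds shown leave open how an amine, a carboxylic acid or a longer chain in place of the methyl or methoxy would read on either aryl group. A value for the 4-methylphenyl compound inside the measurable range would also be needed before the two cores could be compared.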